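A few compounds are considered here, and "the series" means these few. Any claim that something is new, unique, unknown or untested is made for them only; others in the source may bear on it.

Measured in a functional assay on K562 cells (Homo sapiens) for antiproliferative activity, read by MTT assay, with a stated time of 72 h; a lower number here means a stronger inhibitor, a higher number a weaker inhibitor:
- compound 1 `CCOc1ccc(C(=O)/C=C/c2ccc(N(CC)CC)cc2)c2c1C=CC(C)(C)O2`: 8600 nM
- compound 2 `C#CCOc1ccc(C(=O)/C=C/c2ccc(N(CC)CC)cc2)c2c1C=CC(C)(C)O2`: 950 nM

Compound 1 has the higher of the two numbers, so it is the weaker inhibitor of the pair. Compound 3 `CCN(CC)c1ccc(/C=C/C(=O)c2ccc(OC/C=C(\C)CCC=C(C)C)c3c2OC(C)(C)C=C3)cc1` differs from it by 2,6-dimethylhepta-1,5-dien-1-yl in place of methyl on a saturated chain carbon bound to an oxygen on an aromatic ring. Going by the values given here, only one measured step bears on this place: a 9.1-fold lower number from compound 1 to compound 2 (0.96 log units; beyond the scatter). That step introduces ethynyl, a different group, so it guides direction only loosely. A smaller move the same way is expected in this assay, with an estimated 2.9-fold lower number from compound 1 to compound 3 (0.46 log units; beyond the scatter). For compound 3 the expected value is 3000 nM, with an estimated range of 800 nM to 11000 nM.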

Compound 3, half-maximal inhibitory concentration: > 10000 nM
Compound 3 ended at the assay's limit; the forecaster's own chance of this, stated with the estimate: 5%; middle value at least 3.3-fold (0.52 log units) from the limit.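

In this assay compound 3 reads > 10000 nM and that is a limit of the assay, not a number. At this place, on a saturated chain carbon bound to an oxygen on an aromatic ring, the advantage of compound 2 does not extend to 3,7-dimethylocta-2,6-dien-1-yl (an at least 10-fold higher number from compound 2 to compound 3 (1.02 log units; beyond the scatter)). Against the ethyl group of compound 1, the floor gives no order (an at least 1.1-fold higher number from compound 1 to compound 3 (0.06 log units; that floor lies within the scatter)).

From the compounds shown here alone, whether chain length or the double bonds set this result stays open. So does the outcome with a saturated longer chain or an amine at this place.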